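This account rests on a few compounds, and the source may have more. Where it says the series, first, only, none or still open, it means among the compounds named here.

Compound 1 `COc1ccc(-c2cccc(S(=O)(=O)N3CCC(N4CCC(C)CC4)CC3)c2)cc1`: 23 nM
Compound 2 `CC(=O)Nc1ccc(S(=O)(=O)N2CCC(N3CCC(C)CC3)CC2)c2ccccc12`: 1100 nM

In a functional assay on DLD-1 cells (Homo sapiens) for antiproliferative activity, read by CellTiter-Glo, with a stated time of 72 h (a lower number here means a stronger inhibitor, a higher number a weaker inhibitor), compound 1 gives 23 nM, the lower of the two numbers. Compound 2 gives 1100 nM, a far higher number, a gap that lies beyond the usual scatter. Going by the values given here, no pair of measured compounds differs in just one place, so no single step can be read from these numbers.

Compound 3 `Cc1ccc(-c2cccc(S(=O)(=O)N3CCC(N4CCC(C)CC4)CC3)c2)cc1` differs from compound 1 in one place: methyl in place of methoxy on an aromatic carbon. Among the compounds with values here, with no measured step of this kind to lean on, the step from compound 1 to compound 3 is expected to be small, a 1.5-fold higher number from compound 1 to compound 3 (0.18 log units; within the scatter), not clearly beyond the scatter. Compound 3 is estimated at 35 nM, within a range of 12 nM to 110 nM.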

Compound 3, half-maximal inhibitory concentration: 11 nM
The estimate for compound 3 lay 3.2-fold (0.50 log units) above the measured number; measured number below the stated range.
By their numbers in this assay, from the lowest: compound 3; then compound 1; then compound 2.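

In this assay, going by these compounds alone, this is the first change at a single place that can be read, and it gives a 2.1-fold lower number from compound 1 to compound 3 (0.32 log units; beyond the scatter), a modest step. The oxygen of the methoxy group, on this aromatic carbon para to a large group, is therefore not required for activity in these cells: the 4-methylphenyl compound is the stronger inhibitor. Nothing shown explains why the number falls. As far as these compounds go, whether an ethyl group, a chlorine atom or an amine at this place would lower the number further stays open. So does whether the same swap would give a similar step on another core.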